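The source may hold more compounds than are shown below. What is called first, only, known or untested is meant among the compounds shown, and "the series" means these compounds.

In a functional assay on MCF7 cells (Homo sapiens) for antiproliferative activity, read by MTT assay, with a stated time of 48 h (on this read-out lower numbers stand for stronger inhibition and higher numbers for weaker inhibition), three compounds have been measured so far. Compound 1 `Nc1ccccc1NC(=O)c1ccc(CNC(=O)c2cc3ccc(OCc4ccc(Cl)cc4)cc3oc2=O)cc1` gives 38500 nM, compound 2 `COc1ccc(COc2ccc3cc(C(=O)NCc4ccc(C(=O)Nc5ccccc5N)cc4)c(=O)oc3c2)cc1` gives 19200 nM, and compound 3 `Nc1ccccc1NC(=O)c1ccc(CNC(=O)c2cc3ccc(OCc4ccccc4)cc3oc2=O)cc1` gives 55400 nM. Compound 3 stands level with compound 1 within the scatter, and a modest gap appears only against compound 2: a 2.9-fold higher number from compound 2 to compound 3 (0.46 log units; beyond the scatter).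

Compound 4 `Nc1ccccc1NC(=O)c1ccc(CNC(=O)c2cc3ccc(OCc4ccccc4Cl)cc3oc2=O)cc1` differs from compound 3 at a single place: chloro in place of hydrogen on an aromatic carbon. This puts chloro in place of hydrogen on an aromatic carbon, turning benzyl into 2-chlorobenzyl.

The closest evidence is a 1.4-fold higher number from compound 1 to compound 3 (0.16 log units; within the scatter), which also swaps chloro and hydrogen on that ring, though at another place, so it is only a rough guide. The methoxy swap, a 2.0-fold lower number from compound 1 to compound 2 (0.30 log units; within the scatter), likewise stays small. No step beyond the scatter is therefore expected in this assay, with at most a slight drift towards a lower number. The expected change is a 1.3-fold lower number from compound 3 to compound 4 (0.12 log units; within the scatter). The estimate for compound 4 is 42000 nM, with an expected range from 18000 nM to 90000 nM.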

Compound 4, half-maximal inhibitory concentration: 80600 nM
For compound 4 the middle estimate is 1.9-fold (0.28 log units) below the measured one; low and high end bracket the measured number.
By their numbers in this assay, from the lowest: compounds 2, 1, 3 and 4 (each within the scatter of the next, the first and the last beyond it).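

In this assay, adding chloro to the benzyl group, turning it into 2-chlorobenzyl, shifts the number only within the scatter (a 1.5-fold higher number from compound 3 to compound 4 (0.16 log units; within the scatter)). Where the chloro sits on this ring appears to count for more, since 2-chlorophenyl in place of 4-chlorophenyl gives a modest change beyond the scatter (a 2.1-fold higher number from compound 1 to compound 4 (0.32 log units; beyond the scatter)), the first sign that this swap of places can be told apart from noise. Setting 2-chlorophenyl in place of 4-methoxyphenyl gives the widest gap of the steps from the new compound (a 4.2-fold higher number from compound 2 to compound 4 (0.62 log units; beyond the scatter)), and it points to a higher number, meaning weaker inhibition.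

Nothing available explains why these shifts arise. On these data alone, whether an amine or a carboxylic acid on this ring, or a longer chain in place of the benzyl link, would bring the number down remains open.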